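Aryl Piperazine Variation and Metabolic Half-Life

The compounds below may be only part of what the source reports. "The series", "measured", "known", "first", "only" and "open" are said of these compounds alone.

Measured compounds:
- compound 1, `O=C(NCCCCN1CCN(c2ccccc2)CC1)c1ccc(-c2ccsc2)cc1`: 0.41 h
- compound 2, `O=C(NCCCCN1CCN(c2cccc(Cl)c2)CC1)c1ccc(-c2ccsc2)cc1`: 0.468 h
- compound 3, `Cc1cccc(N2CCN(CCCCNC(=O)c3ccc(-c4ccsc4)cc3)CC2)c1`: 0.372 h

In an ADME assay on microsomes from liver (Rattus norvegicus) for metabolic stability, read by LC-MS, using NADPH (a higher number here means that the compound lasts longer, a lower number that the compound disappears faster), compound 3 gives the lowest of the three numbers, but its gaps to compound 1 and compound 2 both fall within the scatter, so no order among them can be claimed. Compound 4, `O=C(NCCCCN1CCN(c2ccccc2C(F)(F)F)CC1)c1ccc(-c2ccsc2)cc1`, differs from compound 3 by 2-(trifluoromethyl)phenyl in place of 3-methylphenyl on an amine nitrogen in a ring. The measured steps all change the group on this same phenyl ring: a 1.1-fold higher number from compound 1 to compound 2 (0.06 log units; within the scatter), a 1.1-fold lower number from compound 1 to compound 3 (0.04 log units; within the scatter) and a 1.3-fold lower number from compound 2 to compound 3 (0.10 log units; within the scatter), none beyond the scatter. Going by the values given here, no measured step covers a trifluoromethyl group, so the change from compound 3 to compound 4 is expected to stay within the scatter, as a 1.1-fold higher number from compound 3 to compound 4 (0.05 log units; within the scatter). Compound 4 is therefore estimated at 0.42 h, between 0.2 h and 0.9 h.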

Compound 4, half-life: 0.0667 h
Beside the measured number, compound 4's estimate is 6.3-fold (0.80 log units) above it, and the stated range ends above it.
By their numbers in this assay, from the lowest: compound 4; then compounds 3, 1 and 2 (each within the scatter of the next).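

In this assay the group on this ring nitrogen turns out to matter: the chloro and methyl changes left the half-life within the scatter, but 2-(trifluoromethyl)phenyl gives a 6.1-fold lower number from compound 1 to compound 4 (0.79 log units; beyond the scatter) and a 5.6-fold lower number from compound 3 to compound 4 (0.75 log units; beyond the scatter) and a 7.0-fold lower number from compound 2 to compound 4 (0.85 log units; beyond the scatter). So the flat picture from the first three compounds does not extend to every group on this phenyl ring. Nothing available here explains the drop. On these data alone, compound 4 changes the group and its place on the ring together, so what the trifluoromethyl group does elsewhere on the ring stays open. As far as these compounds go, how a methoxy group or a nitrile would behave on this ring also stays open.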